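A few compounds are considered here, and "the series" means these few. Any claim that something is new, unique, unknown or untested is made for them only; others in the source may bear on it.

Three amides built on a shared core have been measured in an assay on HeLa cells with Bile acid receptor (Homo sapiens) as the target, read by a luciferase reporter, with a stated time of 24 h; on this read-out higher numbers stand for an effect only at larger amounts of compound and lower numbers for an effect already at smaller amounts. Compound 1 `CC(C)(C)c1ccc(C(=O)NCc2ccc(C(=O)O)cc2F)cc1` gives 7.8 nM. Compound 2 `CC(C)(C)c1ccc(C(=O)NCc2ccc(NC(=O)C(F)(F)F)cc2Cl)cc1` gives 14 nM, a number that lies within the usual scatter of the value of compound 1, so the two cannot be told apart. Compound 3 `CN(C)C(=O)c1ccc(CNC(=O)c2ccc(C(C)(C)C)cc2)cc1` gives 170 nM, which stands beyond the scatter above the value of compound 2. Among these three numbers, compound 2 therefore holds the second highest place, close to compound 1 and well apart from compound 3.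

Compound 4 `CC(C)(C)c1ccc(C(=O)NCc2ccc(N)cc2Cl)cc1` has not yet been measured. It differs from compound 2 in one place: hydrogen in place of (trifluoromethyl)carbonyl on a nitrogen on an aromatic ring. Going by the values given here, no measured pair in this set shows this exact change, so its effect must be guessed from the spread of the three numbers alone.

For compound 4 the expectation is a step from compound 2 of a 7.1-fold higher number from compound 2 to compound 4 (0.85 log units; beyond the scatter), towards a higher number beyond the scatter. Compound 4 is therefore estimated at 100 nM, in a range from 20 nM to 600 nM.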

Compound 4, half-maximal effective concentration: 46 nM
For compound 4 the middle estimate is 2.2-fold (0.34 log units) above the measured one; the range from low to high includes it.
By their numbers in this assay, from the lowest: compounds 1 and 2 (each within the scatter of the next); then compound 4; then compound 3.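

Taking the (trifluoromethyl)carbonyl off the nitrogen on the aromatic ring gives, in this assay, a 3.3-fold higher number from compound 2 to compound 4 (0.52 log units; beyond the scatter) and leaves a plain amino group. This is the first change in one place among these compounds, and it shows that the group matters at this position, though only modestly: without it, compound 4 still gives 46 nM, so an effect remains at low amounts of compound. Nothing measured here explains why the number moves.

The compounds shown do not tell whether the step comes from the carbonyl or from the trifluoromethyl part; an acetyl group on the same nitrogen would separate the two. From the compounds shown here alone, how the same change would read with a fluorine in place of the chlorine also stays open.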